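Removing One Benzyloxy Group from Compound 3

A few compounds are considered here, and "the series" means these few. Any claim that something is new, unique, unknown or untested is made for them only; others in the source may bear on it.

Compound 3 `N/N=C\c1cc(=O)oc2cc(OCc3ccccc3)cc(OCc3ccccc3)c12` stands highest of the three numbers in a functional assay, read by spectrophotometry, with a stated time of 3 min (a lower number here means a stronger inhibitor, a higher number a weaker inhibitor), where compound 3 gives 363000 nM. For the measured compounds named here, compound 1 `Nc1ccccc1/N=C\c1cc(=O)oc2cc(OCc3ccccc3)ccc12` gives 9250 nM and compound 2 `O=c1cc(/C=N\c2ccccc2O)c2ccc(OCc3ccccc3)cc2o1` gives 1290 nM; the only measured step, a 7.2-fold lower number from compound 1 to compound 2 (0.86 log units; beyond the scatter), concerns a change in another part of the molecule and does not bear on the present one. Compound 4 `N/N=C\c1cc(=O)oc2cc(OCc3ccccc3)ccc12` differs from compound 3 by hydrogen in place of benzyloxy on an aromatic carbon. Going by the values given here, no measured step follows this change. Compounds 1 and 2 also carry a single benzyloxy group, but they differ from compound 4 in more than one place, so their much lower numbers are only a loose pointer. The step of a 4.5-fold lower number from compound 3 to compound 4 (0.66 log units; beyond the scatter) is thus expected to be modest and uncertain in size. Compound 4 is estimated at 80000 nM, within 10000 nM to 500000 nM.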

Compound 4, half-maximal inhibitory concentration: 9740 nM
Compound 4: middle estimate off by 8.2-fold (0.91 log units), on the high side; measured number below the stated range.
By their numbers in this assay, from the lowest: compound 2; then compounds 1 and 4 (each within the scatter of the next); then compound 3.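

In this assay the benzyloxy group on the aromatic carbon ortho to a fused ring proves costly: hydrogen in its place gives a large step (a 37-fold lower number from compound 3 to compound 4 (1.57 log units; beyond the scatter)). With that carbon bearing hydrogen, amino and 2-aminophenyl on the double-bonded nitrogen are not told apart (a 1.1-fold higher number from compound 1 to compound 4 (0.02 log units; within the scatter)), whereas 2-hydroxyphenyl remains distinct (a 7.6-fold higher number from compound 2 to compound 4 (0.88 log units; beyond the scatter)). Nothing available explains these steps. Going by these compounds, it remains open whether a methoxy or hydroxy group on this carbon would track compound 3 or compound 4. On these data alone, whether a second benzyloxy group carries the same penalty alongside 2-hydroxyphenyl also remains open.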